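The source may report more compounds than this note shows. Statements on the series, on what has been measured and on what is new or still open speak of the compounds shown alone.

Of the compounds shown here, three have so far been measured in a functional assay on PANC-1 cells (Homo sapiens) for inhibition, read by MTT assay, with a stated time of 72 h; on this read-out lower numbers stand for stronger inhibition of growth and higher numbers for weaker inhibition of growth. Compound 1 `O=S(=O)(NCCCCNCc1ccc(Br)cc1)c1cc(C(F)(F)F)cc(C(F)(F)F)c1` gives 2200 nM. Compound 3 `CC(C)(C)c1ccc(CNCCNS(=O)(=O)c2cc(C(F)(F)F)cc(C(F)(F)F)c2)cc1` gives 13000 nM. Compound 2 `CN(CCCNS(=O)(=O)c1cc(C(F)(F)F)cc(C(F)(F)F)c1)Cc1ccccc1` reaches only the limit of the assay, > 50000 nM, so for compound 2 there is no number but a limit (the limit of > 50000 nM in this assay, at which 1 of the 3 values shown sits).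

Compound 4 `O=S(=O)(NCCCNCc1cccc(Cl)c1)c1cc(C(F)(F)F)cc(C(F)(F)F)c1` differs from compound 2 by (3-chlorobenzyl)amino in place of benzyl(methyl)amino on a saturated chain carbon, three bonds along the chain from a sulfonamide nitrogen. Going by the values given here, the one measured step that bears on this change is an at least 22-fold higher number from compound 1 to compound 2 (1.35 log units; beyond the scatter), in which the same kind of exchange ran the other way, from a (4-bromobenzyl)amino group to benzyl(methyl)amino, and left compound 2 at the limit. Running the exchange back, now with a (3-chlorobenzyl)amino group, is therefore expected to give a large step in the direction of stronger inhibition, toward the region where compound 1 and compound 3 sit; those two carry different chain lengths and ring substituents, so the return need not reach the number of compound 1 exactly. Compound 4 is expected to give 4500 nM, with a range from 1500 nM to 15000 nM. That expectation amounts to an at least 11-fold lower number from compound 2 to compound 4 (1.04 log units; beyond the scatter) in this assay.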

Compound 4, concentration for 50% growth inhibition: 12000 nM
Compound 4: middle estimate off by 2.7-fold (0.43 log units), on the low side, and the stated range covers the measured number.
By their numbers in this assay, from the lowest: compound 1; then compounds 4 and 3 (each within the scatter of the next). At a limit, above all of these: compound 2.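

In this assay, the exchange on the saturated chain carbon, three bonds along the chain from a sulfonamide nitrogen, now has a reading toward stronger inhibition, with (3-chlorobenzyl)amino in place of benzyl(methyl)amino giving an at least 4.1-fold lower number from compound 2 to compound 4 (0.61 log units; beyond the scatter). Compound 2 has only a limit, so this step is a bound and not a full size: the limit of > 50000 nM in this assay, at which 1 of the 4 values shown sits. The recovery is only partial, as (3-chlorobenzyl)amino in place of ((4-bromobenzyl)amino)methyl gives a 5.5-fold higher number from compound 1 to compound 4 (0.74 log units; beyond the scatter).

The exchange from compound 2 to compound 4 removes the methyl on the nitrogen and adds the chlorine in one move, and the compounds shown do not separate the two. Going by these compounds, it also remains open how a plain benzylamino group on this chain would read, and whether a longer chain carrying (3-chlorobenzyl)amino would match compound 1.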